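One Fluoro Group Fewer: From Compound 1 to Compound 4

This account rests on a few compounds, and the source may have more. Where it says the series, first, only, none or still open, it means among the compounds named here.

In an ADME assay on BJ cells (Homo sapiens) for cytotoxicity, with a stated time of 72 h (a higher number here means that more compound is needed for the effect, a lower number that less compound is needed), compound 1 `Cc1cc(NC(=O)Nc2cc(F)ccc2F)c2ccccc2n1` gives 7000 nM. Among the compounds with values here, that is the only actual number in this set. Compound 2 `Cc1cc(NC(=O)Nc2ccc3[nH]cnc3c2)c2ccccc2n1` reaches only a limit of the assay, > 25000 nM, with no number behind it. Compound 3 `Cc1cc(NC(=O)Nc2ccc(C(N)=O)cc2)c2ccccc2n1` likewise stops at a limit, > 25000 nM. Compound 1 therefore stands alone as a measured value, while the limit of > 25000 nM in this assay, at which 2 of the 3 values shown sit, covers the other two.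

Compound 4 `Cc1cc(NC(=O)Nc2cccc(F)c2)c2ccccc2n1` has not yet been measured. It differs from compound 1 in one place: hydrogen in place of fluoro on an aromatic carbon. Within the data shown here, no step between measured compounds exists to guide the size of this change, so only a small shift is expected, in either direction or none beyond the scatter. For compound 4 the estimated result in this assay is 10000 nM, with a range from 4000 nM to 25000 nM. That estimate corresponds to an expected step of a 1.4-fold higher number from compound 1 to compound 4 (0.15 log units; within the scatter).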

Compound 4, half-maximal effective concentration: > 25000 nM
Compound 4 was reported as a limit; the forecaster's own chance of this, stated with the estimate: 30%; middle value at least 2.5-fold (0.39 log units) away from the limit.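

On this aromatic carbon, ortho to a large group and para to a fluoro group, hydrogen in place of fluoro gives an at least 3.5-fold higher number from compound 1 to compound 4 (0.55 log units; beyond the scatter) in this assay. Within the data shown here, this is the first step in the set that can be read, and it shows that a single fluoro group at this place can matter in this assay. The step gives only a minimum size: the limit of > 25000 nM in this assay, at which 3 of the 4 values shown sit.

As far as these compounds go, how far compound 4 lies past that limit remains unknown. Also open, from the compounds shown here alone, is what a chlorine atom, a methyl group or an amine would do on the same carbon.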